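The source may report more compounds than this note shows. Statements on the series, on what has been measured and on what is new or still open speak of the compounds shown alone.

In a functional assay on PC-3 cells (Homo sapiens) for cytotoxicity, read by WST assay, with a stated time of 72 h (a lower number here means a stronger inhibitor, a higher number a weaker inhibitor), compound 1 `O=C1Nc2c(ccc(F)c2F)C1(c1ccc(O)cc1)c1ccc(F)cc1` gives 8.6 nM. Compound 2 `O=C1Nc2c(ccc(F)c2F)C1(c1ccc(O)cc1)c1cccnc1` gives > 1000 nM, which is a limit of the assay and not a number. As far as these compounds go, compound 3 `CCCC1(c2ccc(O)cc2)C(=O)Nc2c1ccc(F)c2F` gives > 1000 nM, which is likewise a limit, so its exact place on the scale is unknown. With pyridin-3-yl in place of 4-fluorophenyl on a saturated ring carbon, the data show an at least 110-fold higher number from compound 1 to compound 2 (2.06 log units; beyond the scatter). With propyl in place of 4-fluorophenyl there, they show an at least 110-fold higher number from compound 1 to compound 3 (2.06 log units; beyond the scatter). With propyl in place of pyridin-3-yl, they show a step that the two limits leave unreadable from compound 2 to compound 3.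

Compound 4 `CCCCCC1(c2ccc(O)cc2)C(=O)Nc2c1ccc(F)c2F` takes the propyl chain of compound 3 to pentyl: ethyl in place of hydrogen on a saturated chain carbon, three bonds along the chain from a saturated ring carbon. Among the compounds with values here, the two large steps replace the 4-fluorophenyl group itself, and no measured step lengthens a chain, so they bear on this change only indirectly. Only a small shift in this assay is expected, perhaps toward a lower number, and another limit is quite possible. The expected change is a step that the limit leaves unreadable from compound 3 to compound 4. For compound 4 the estimate is 1500 nM, with an expected range from 400 nM to 5000 nM.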

Compound 4, half-maximal inhibitory concentration: 1.1 nM
Compound 4: middle estimate off by 1400-fold (3.13 log units), on the high side; the whole stated range lies above it.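

Lengthening the chain on this saturated ring carbon matters far more in this assay than the earlier compounds suggested, with an at least 900-fold lower number from compound 3 to compound 4 (2.95 log units; beyond the scatter). Until now, every replacement of 4-fluorophenyl had cost activity, but the pentyl chain gives a 7.8-fold lower number from compound 1 to compound 4 (0.89 log units; beyond the scatter), so a ring is not required there for a low number, and the pentyl chain also gives an at least 900-fold lower number from compound 2 to compound 4 (2.95 log units; beyond the scatter). The values of compound 2 and compound 3 are limits and not numbers: the limit of > 1000 nM in this assay, at which 2 of the 4 values shown sit.

With only propyl and pentyl shown, the compounds leave open how the number runs with chain length, and whether butyl falls in between or hexyl goes lower still. They also leave open whether a chain carrying an amine or a carboxylic acid would keep the low number of compound 4.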